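The source may report more compounds than this note shows. Statements on the series, on what has been measured and on what is new or still open speak of the compounds shown alone.

Compound 1 `CC(O)(COc1cccc(C(F)(F)F)c1)C(=O)Nc1ccc(S(F)(F)(F)(F)F)cc1` and compound 2 `CC(O)(COc1cccc(OC(F)(F)F)c1)C(=O)Nc1ccc(S(F)(F)(F)(F)F)cc1` share one core and differ in a single place: trifluoromethoxy in place of trifluoromethyl on an aromatic carbon. In a functional assay on CWR22R cells (Homo sapiens) for antiproliferative activity, read by propidium iodide staining, with a stated time of 96 h (on this read-out lower numbers stand for stronger inhibition and higher numbers for weaker inhibition), compound 1 gives 14600 nM, while compound 2 gives 17300 nM. That step, a 1.2-fold higher number from compound 1 to compound 2 (0.07 log units; within the scatter), leaves the two compounds within the scatter of each other, so neither can be called the more or less active of the pair.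

Compound 3 `CC(O)(COc1cccc(C(F)(F)F)c1)C(=O)Nc1cccc(S(F)(F)(F)(F)F)c1` is built from the same atoms as compound 1, joined differently; the difference between the two cores is not broken down here. In this assay compound 3 gives 28900 nM, a figure that also lies within the scatter of both compound 1 and compound 2.

Compound 4 `CC(O)(COc1cccc(OC(F)(F)F)c1)C(=O)Nc1cccc(S(F)(F)(F)(F)F)c1` stands to compound 3 as compound 2 stands to compound 1, through the same change: trifluoromethoxy in place of trifluoromethyl on an aromatic carbon. Because the earlier instance of this change gave a 1.2-fold higher number from compound 1 to compound 2 (0.07 log units; within the scatter), the same change on the core of compound 3 is expected to move the number little, and a step of about a 1.2-fold higher number from compound 3 to compound 4 (0.07 log units; within the scatter) is estimated from compound 3 to compound 4. On that basis compound 4 is expected to give roughly 34000 nM in this assay, with a likely range from 19000 nM to 62000 nM. That expectation rests on one earlier pair alone, so its footing is narrow.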

Compound 4, half-maximal inhibitory concentration: 18800 nM
For compound 4 the middle estimate is 1.8-fold (0.26 log units) above the measured one, outside the stated range (below it).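

In this assay, putting trifluoromethoxy in place of trifluoromethyl on the core of compound 3 gives a 1.5-fold lower number from compound 3 to compound 4 (0.19 log units; within the scatter), a step that does not separate the two compounds. For the compounds shown here, the two instances of this change, on two different cores, can be read as the same result, with neither step telling its pair apart and no difference between the steps that exceeds the scatter: the same change on two cores in this assay, a 1.2-fold higher number (0.07 log units; within the scatter) from compound 1 to compound 2 and a 1.5-fold lower number (0.19 log units; within the scatter) from compound 3 to compound 4, 1.8-fold (0.26 log units) apart, within the scatter of two such steps What this does not show is that the core has no influence on the change, or that the change would behave alike on any further core, since it rests on just two pairs whose steps all lie within the scatter, and the opposite directions printed for the two steps cannot be read as a real reversal.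

The compounds shown leave open whether a different group in the place of trifluoromethyl and trifluoromethoxy, such as a nitrile, a chlorine or an amine, would move the number beyond the scatter. They also leave open what would follow if the hydroxyl group of the shared chain were exchanged for an amine or a methoxy group.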